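The source may hold more compounds than are shown below. What is called first, only, known or untested is meant among the compounds shown, and "the series" means these compounds.

Values measured in a functional assay on HepG2 cells (Homo sapiens) for inhibition, read by MTT assay, with a stated time of 24 h (on this read-out higher numbers stand for weaker inhibition and lower numbers for stronger inhibition), for the series:
compound 1 `CC1(C)[C@H]2CC[C@]1(C)N(Cc1cn(-c3ccc(F)cc3)nn1)C(=O)C2` gives 90 nM
compound 2 `CC1(C)[C@H]2CC[C@]1(C)N(Cc1cn(-c3ccccc3Cl)nn1)C(=O)C2` gives 60 nM
compound 3 `CC1(C)[C@H]2CC[C@]1(C)N(Cc1cn(-c3ccccc3O)nn1)C(=O)C2` gives 120 nM

On these numbers compound 3 cannot be separated from the other two measured compounds. The relevant steps are a 1.3-fold higher number from compound 1 to compound 3 (0.12 log units; within the scatter) and a 2.0-fold higher number from compound 2 to compound 3 (0.30 log units; within the scatter), and neither supports a ranking.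

Compound 4 `CC1(C)[C@H]2CC[C@]1(C)N(Cc1cn(-c3cccc(Br)c3)nn1)C(=O)C2` has 3-bromophenyl in place of 2-hydroxyphenyl on an aromatic nitrogen, the same place at which the measured compounds differ. All three measured steps therefore bear on it. Besides the two above, the third is a 1.5-fold lower number from compound 1 to compound 2 (0.18 log units; within the scatter). None of these aryl exchanges has moved the value beyond the scatter. Going by the values given here, no measured compound carries a bromine, so this comparison is only indirect.

No step beyond the scatter is therefore expected in this assay, and no firm direction can be given. The estimated change is a 1.3-fold lower number from compound 3 to compound 4 (0.12 log units; within the scatter) as a working figure. Compound 4 is expected at an estimated 90 nM, with an expected range of 40 nM to 200 nM as the likely span.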

Compound 4, half-maximal inhibitory concentration: 20 nM
The estimate for compound 4 lay 4.5-fold (0.65 log units) above the measured number; the whole stated range lies above it.
By their numbers in this assay, from the lowest: compound 4; then compounds 2, 1 and 3 (each within the scatter of the next).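

In this assay, the aryl group on the aromatic nitrogen can move the value beyond the scatter, which no exchange among compound 1, compound 2 and compound 3 did: 3-bromophenyl gives a 6.0-fold lower number from compound 3 to compound 4 (0.78 log units; beyond the scatter) against 2-hydroxyphenyl, a 3.0-fold lower number from compound 2 to compound 4 (0.48 log units; beyond the scatter) against 2-chlorophenyl and a 4.5-fold lower number from compound 1 to compound 4 (0.65 log units; beyond the scatter) against 4-fluorophenyl. All three steps point towards stronger inhibition, so compound 4 stands apart from the other three compounds at this position. No measurement at hand accounts for this shift.

Bromine occurs only in compound 4, and its aryl group differs from each of the others in both substituent and ring place, so the contributions of the halogen and its place cannot be separated. On these data alone, how a 3-iodophenyl or 3-aminophenyl group would read in this assay also remains open.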